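A few compounds are considered here, and "the series" means these few. Any claim that something is new, unique, unknown or untested is made for them only; others in the source may bear on it.

Three measured compounds share one core and differ only in the group attached through a methylene linker. Compound 1 `CCOC(=O)[C@H](CCC(=O)O)NC(=O)c1ccc(CNc2nc3cc(N)cc(N)c3nc2-c2ccccc2)cc1` gives, in a functional assay on NCI-H522 cells (Homo sapiens) for inhibition, read by sulforhodamine B assay, with a stated time of 48 h (on this read-out lower numbers stand for stronger inhibition of growth and higher numbers for weaker inhibition of growth), a value of 26900 nM. Within the data shown here, compound 2 `COc1ccc(CNc2nc3cc(N)cc(N)c3nc2-c2ccccc2)cc1OC` gives 2690 nM in this assay, the lowest of the two numbers available; the only other number, that of compound 1, stands higher by a gap beyond the usual scatter. For compound 3 `COc1cc(CNc2nc3cc(N)cc(N)c3nc2-c2ccccc2)cc(OC)c1OC` this assay reports only a limit, < 50200 nM. The step from compound 2 to compound 3 therefore cannot be read as a size, a step that the limit leaves unreadable from compound 2 to compound 3, because of the limit (the limit of < 50200 nM in this assay, at which 1 of the 3 values shown sits).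

Compound 4 `COc1ccc(CNc2nc3cc(N)cc(N)c3nc2-c2ccccc2)cc1` is not yet measured. It differs from compound 2 by hydrogen in place of methoxy on an aromatic carbon. Among the measured compounds shown here, the only measured step that touches a methoxy on that same ring is the one from compound 2 to compound 3, and that one is unreadable, so no step of known size bears on this change. With nothing pointing in either direction, the expectation for compound 4 is a step of a 1.1-fold higher number from compound 2 to compound 4 (0.05 log units; within the scatter), not beyond the scatter. Compound 4 is therefore estimated at 3000 nM in this assay, expected to fall between 1000 nM and 10000 nM.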

Compound 4, concentration for 50% growth inhibition: 10000 nM
The estimate for compound 4 lay 3.3-fold (0.52 log units) below the measured number, and the stated range covers the measured number.
By their numbers in this assay, from the lowest: compound 2; then compound 4; then compound 1.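

In this assay, the change from 3,4-dimethoxyphenyl to 4-methoxyphenyl, hydrogen in place of methoxy on an aromatic carbon, gives a 3.7-fold higher number from compound 2 to compound 4 (0.57 log units; beyond the scatter). Among these compounds, this is the first readable step on this ring, and it shows that the position ortho to a methoxy group and meta to a large group is not indifferent: a methoxy there goes with stronger inhibition of growth than a plain hydrogen, and the single remaining methoxy of compound 4 does not hold the level of compound 2. Nothing measured in these compounds says why this change moves the number.

On these data alone, compound 3 gives only a limit, < 50200 nM, so the step from compound 2 to compound 3 cannot be read and the effect of adding a further methoxy to this ring stays unknown. The compounds shown also leave open whether the gain belongs to methoxy itself or would be kept by another group at this position, such as a hydroxyl, a chlorine or an amine.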